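The source may hold more compounds than are shown below. What is called first, only, known or untested is meant among the compounds shown, and "the series" means these compounds.

Working notes on the pyridyl series in an assay on isolated protein for inhibition of DNA topoisomerase 1 (Homo sapiens), with a stated time of 30 min, tested at 100 uM; on this read-out higher numbers stand for a stronger effect at the one concentration tested and lower numbers for a weaker effect.

Of the compounds shown here, three have numbers so far. Compound 1 `Oc1cccc(-c2cc(-c3cccnc3)nc(-c3cccc(Cl)c3)c2)c1` gives 27.6% in this assay. Compound 2 `Oc1ccc(-c2cc(-c3ccccc3)nc(-c3ccccc3Cl)c2)cc1` gives 13.6% in this assay. Compound 3 `Oc1cccc(-c2cc(-c3ccncc3)nc(-c3cccc(Cl)c3)c2)c1` gives 0% in this assay, the lowest of the three numbers: compound 2 stands nearest to it, beyond the scatter, and compound 1 furthest, also beyond the scatter. Among the compounds with values here, the one measured step that changes a single place is a number 27.6 percentage points lower from compound 1 to compound 3 (beyond the scatter), a pyridin-4-yl in place of a pyridin-3-yl, which by itself carried the series from its highest number to zero.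

Compound 4 `Oc1cccc(-c2cc(-c3cccc(Cl)c3)nc(-c3ccccn3)c2)c1` is not yet measured. The change from compound 3 is pyridin-2-yl in place of pyridin-4-yl on an aromatic carbon, the pyridyl group again sitting on the aromatic carbon next to the ring nitrogen, meta to the 3-chlorophenyl group and meta to the 3-hydroxyphenyl group. Within the data shown here, the only step that bears on it is the one from compound 1 to compound 3, which shows that shifting the nitrogen within the pyridyl ring moves this assay by a modest amount. Among the measured compounds shown here, no measured pair contains a pyridin-2-yl, so the direction is open; since compound 3 sits at zero, only a rise or no change is possible. A small rise, within or close to the scatter, is expected, as a number 10 percentage points higher from compound 3 to compound 4 (within the scatter). For compound 4 the estimate is 10%, ranging from 0% to 30%.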

Compound 4, a percentage reported as inhibition, at one concentration (the size of the read-out at that concentration, not a potency): 0.4%
Beside the measured number, compound 4's estimate is 9.6 percentage points above it; low and high end bracket the measured number.
By their numbers in this assay, from the lowest: compounds 3 and 4 (each within the scatter of the next); then compound 2; then compound 1.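

In this assay, the new step is a number 0.4 percentage points higher from compound 3 to compound 4 (within the scatter), so at this aromatic carbon next to the ring nitrogen, pyridin-2-yl and pyridin-4-yl cannot be told apart. The second step is a number 27.2 percentage points lower from compound 1 to compound 4 (beyond the scatter), which goes the same way as a number 27.6 percentage points lower from compound 1 to compound 3 (beyond the scatter) and is likewise beyond the scatter, so the loss seen earlier was not peculiar to pyridin-4-yl and pyridin-3-yl now stands apart from both other pyridyl groups in this small set. No measurement available here explains why the position of the pyridyl nitrogen matters in this way.

From the compounds shown here alone, it remains open whether the number held by compound 1 at 27.6% depends on the pyridin-3-yl ring itself or could be matched or exceeded by a different group at this carbon, such as an aminomethyl group, a carboxylic acid or a morpholine ring. Going by these compounds, it is also open whether a substituent on the pyridin-3-yl ring, such as a methoxy group or an amine, would raise or lower the read-out in this assay.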